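The source may report more compounds than this note shows. Statements on the series, on what has been measured and on what is new or still open speak of the compounds shown alone.

Compound 1 `Cn1c(=O)c(S(=O)(=O)c2ccc(F)cc2F)cc2cnc(Nc3ccncn3)nc21` stands at the weaker end of the two compounds measured in a functional assay on DU-145 cells (Homo sapiens) for inhibition, read by trypan blue exclusion, with a stated time of 72 h; a higher number here means a weaker inhibitor, a lower number a stronger inhibitor. In this assay compound 1 gives 50000 nM, the higher of the two numbers, whereas compound 2 `Cn1c(=O)c(S(=O)(=O)c2ccc(Cl)cc2)cc2cnc(Nc3ccc4[nH]ccc4c3)nc21` gives 250 nM, a far lower number that lies well beyond the usual scatter; the two compounds differ in more than one place, so no single change accounts for this gap. Compound 3 `Cn1c(=O)c(S(=O)(=O)c2ccc(F)cc2F)cc2cnc(Nc3ccc4c(c3)C(=O)C(=O)N4)nc21` keeps the sulfone of compound 1 and differs from it in one place: a group of 11 heavy atoms (8 carbon, 1 nitrogen, 2 oxygen; one five-membered non-aromatic ring with 1 hetero atom, one six-membered aromatic ring of carbon only) in place of a group of 6 heavy atoms (4 carbon, 2 nitrogen; one six-membered aromatic ring with 2 hetero atoms), on a nitrogen on an aromatic ring. Within the data shown here, no measured pair isolates this change, so its effect is only an expectation. Because compound 2 reaches 250 nM, a large downward step is expected, a 50-fold lower number from compound 1 to compound 3 (1.70 log units; beyond the scatter), toward stronger inhibition. Compound 3 is therefore estimated at 1000 nM, with a likely range from 200 nM to 6000 nM.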

Compound 3, half-maximal inhibitory concentration: 75000 nM
Estimate against measurement, compound 3: 75-fold (1.88 log units) below, and the stated range ends below it.
By their numbers in this assay, from the lowest: compound 2; then compounds 1 and 3 (each within the scatter of the next).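

The change on the nitrogen on an aromatic ring, with pyrimidin-4-yl replaced by the group of 11 heavy atoms, gives a 1.5-fold higher number from compound 1 to compound 3 (0.18 log units; within the scatter) in this assay. Among these compounds, this is the first comparison here that isolates this place, and it shows that a larger group with a five-membered non-aromatic ring, a six-membered aromatic ring of carbon only and a hydrogen-bond donor does not by itself separate the two compounds. No available evidence bears on why the two compounds remain so close.

On these data alone, compound 2 differs from both compounds in more than one place, so it remains open which of its differences goes with its 250 nM. Also open, as far as these compounds go, is how a plain phenyl or a phenyl carrying a carboxylic acid would read at this nitrogen on the core of compound 1.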